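Series notes: from compound 2 to compound 4

The source may hold more compounds than are shown below. What is called first, only, known or untested is meant among the compounds shown, and "the series" means these compounds.

Measured in an in vitro ADME assay on microsomes from liver (Homo sapiens) for metabolic stability (on this read-out higher numbers stand for fast clearance and lower numbers for slow clearance), so far
- compound 1 `COc1ccc(C(=O)N2CCC(=CC(=O)N[C@@H]3CCN(Cc4ccc5cc(F)ccc5c4)C3)CC2)cc1` gives 252 mL/min/kg
- compound 2 `Cc1ccc(C(=O)N2CCC(=CC(=O)N[C@@H]3CCN(Cc4ccc5cc(F)ccc5c4)C3)CC2)c(O)c1` gives 156 mL/min/kg
- compound 3 `O=C(C=C1CCN(C(=O)c2ccccc2O)CC1)N[C@@H]1CCN(Cc2ccc3cc(F)ccc3c2)C1` gives < 64 mL/min/kg as a limit of the assay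

Within the data shown here, compound 2 at 156 mL/min/kg stands within the scatter of its only measured neighbour (a 1.6-fold lower number from compound 1 to compound 2 (0.21 log units; within the scatter)). Compound 4 `COc1cccc(C(=O)N2CCC(=CC(=O)N[C@@H]3CCN(Cc4ccc5cc(F)ccc5c4)C3)CC2)c1O` is not yet measured. Its change from compound 2 is 2-hydroxy-3-methoxyphenyl in place of 2-hydroxy-4-methylphenyl on a carbonyl carbon and sits on the same carbonyl carbon. The steps bearing on it are an at least 2.4-fold lower number from compound 2 to compound 3 (0.38 log units; beyond the scatter) and an at least 3.9-fold lower number from compound 1 to compound 3 (0.59 log units; beyond the scatter) and both end at a limit (the limit of < 64 mL/min/kg in this assay, at which 1 of the 3 values shown sits). Among the measured compounds shown here, no measured step adds methoxy to 2-hydroxyphenyl. In this assay no step beyond the scatter is therefore expected, and the estimated step is a 1.3-fold lower number from compound 2 to compound 4 (0.11 log units; within the scatter) for now. For compound 4 the estimated value is 120 mL/min/kg with an expected range from 60 mL/min/kg to 240 mL/min/kg for the measurement.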

Compound 4, clearance: 162 mL/min/kg
For compound 4 the middle estimate is 1.4-fold (0.13 log units) below the measured one, within the range that was stated.
By their numbers in this assay, from the lowest: compounds 2, 4 and 1 (each within the scatter of the next). At a limit, below all of these: compound 3.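

In this assay, 2-hydroxy-3-methoxyphenyl in place of 2-hydroxy-4-methylphenyl gives a 1.0-fold higher number from compound 2 to compound 4 (0.02 log units; within the scatter), and 2-hydroxy-3-methoxyphenyl in place of 4-methoxyphenyl gives a 1.6-fold lower number from compound 1 to compound 4 (0.19 log units; within the scatter), so compounds 1, 2 and 4 read alike within the scatter. Compound 3 carries a limit, and methoxy in place of hydrogen on its aromatic carbon gives an at least 2.5-fold higher number from compound 3 to compound 4 (0.40 log units; beyond the scatter), a size that is only a bound: the limit of < 64 mL/min/kg in this assay, at which 1 of the 4 values shown sits.

Among the compounds shown, only compound 3, with neither methyl nor methoxy on the ring, stands apart. Still open, on these data alone, is whether an amine or a carboxylic acid on this ring would read like methoxy and methyl or like hydrogen.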